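From an Ethyl to an Isopropyl Ester

The source may report more compounds than this note shows. Statements on the series, on what has been measured and on what is new or still open speak of the compounds shown alone.

Compound 1 `CC1=C(C(=O)OC(C)C)C(c2ccsc2)N/C(=N/C#N)N1`: 647 nM
Compound 2 `CCOC(=O)C1=C(C)N/C(=N\C#N)NC1c1ccoc1`: 102 nM

Of the compounds shown here, two have been measured in an assay on HEK293 cells for displacement of a labelled ligand from adenosine receptor A2b (Homo sapiens), with a stated time of 30 min; on this read-out higher numbers stand for weaker inhibition and lower numbers for stronger inhibition. Compound 1 gives 647 nM and compound 2 gives 102 nM, the lower of the two numbers; the gap between them lies beyond the usual scatter. The two differ in more than one place, so this gap cannot be assigned to any single change.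

Compound 3 `CC1=C(C(=O)OC(C)C)C(c2ccoc2)N/C(=N/C#N)N1` has not yet been measured. It differs from compound 2 in one place: methyl in place of hydrogen on a saturated chain carbon bound to an oxygen next to a carbonyl group and a saturated chain carbon. Among the compounds with values here, no measured pair shows this change on its own, so its effect is open. Compound 1 also carries the isopropyl ester and gives the higher number in this assay, but it differs from compound 2 elsewhere too, so it offers no clean guide. A step of modest size, possibly toward a slightly higher number, or none beyond the scatter, is expected, as a 1.8-fold higher number from compound 2 to compound 3 (0.25 log units; within the scatter). Compound 3 is estimated at 180 nM, within 60 nM to 550 nM.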

Compound 3, inhibition constant: 59.4 nM
For compound 3 the middle estimate is 3.0-fold (0.48 log units) above the measured one, and the stated range ends above it.
By their numbers in this assay, from the lowest: compounds 3 and 2 (each within the scatter of the next); then compound 1.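

In this assay, ethyl to isopropyl on the ester gives a 1.7-fold lower number from compound 2 to compound 3 (0.23 log units; within the scatter), so this position accepts the added methyl and the two esters cannot be told apart on this read-out. Compound 3 also gives the first clean view of the group on the saturated ring carbon: furan-3-yl in place of thiophen-3-yl gives an 11-fold lower number from compound 1 to compound 3 (1.04 log units; beyond the scatter), a large step. Among these compounds, then, the ring change moves the number, while the ester change stays within the scatter.

Going by these compounds, whether a longer chain such as butyl, or a carboxylic acid in place of the ester, would be accepted as well remains open. On these data alone, it is also open whether the ring step would hold with the ethyl ester, and nothing available here explains either step.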